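The compounds below may be only part of what the source reports. "The series", "measured", "known", "first", "only" and "open" are said of these compounds alone.

Measured compounds:
compound 1 `COc1cc(C(=O)NS(=O)(=O)c2ccccc2)ccc1Cn1ncc2ccc(NC(=O)CC3CCCC3)cc21` 10.5
compound 2 `COc1cc(C(=O)NS(=O)(=O)c2ccccc2C)ccc1Cn1ccc2ccc(NC(=O)CC3CCCC3)cc21` 9.9
compound 3 `COc1cc(C(=O)NS(=O)(=O)c2cc(C)ccc2C)ccc1Cn1ccc2ccc(NC(=O)CC3CCCC3)cc21` 8.4

Of the compounds shown here, three have been tested in a functional assay (trachea) for antagonist activity, with Cavia porcellus as the target; on this read-out lower numbers stand for lower potency and higher numbers for higher potency (the scale is a negative logarithm). Compound 1 `COc1cc(C(=O)NS(=O)(=O)c2ccccc2)ccc1Cn1ncc2ccc(NC(=O)CC3CCCC3)cc21` gives 10.5, the highest of the three values, and its steps to the other two lie beyond the scatter. Compound 2 `COc1cc(C(=O)NS(=O)(=O)c2ccccc2C)ccc1Cn1ccc2ccc(NC(=O)CC3CCCC3)cc21` gives 9.9 in this assay, and compound 3 `COc1cc(C(=O)NS(=O)(=O)c2cc(C)ccc2C)ccc1Cn1ccc2ccc(NC(=O)CC3CCCC3)cc21` gives 8.4. Compound 1 and compound 2 differ in more than one place, so the difference between the two cores is not broken down here.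

Within the data shown here, the one single step measured so far is the change (methyl in place of hydrogen on an aromatic carbon), which produced a number 1.50 log units lower from compound 2 to compound 3 (beyond the scatter) in this assay. The compound yet to be measured is compound 4 `COc1cc(C(=O)NS(=O)(=O)c2ccccc2C)ccc1Cn1ncc2ccc(NC(=O)CC3CCCC3)cc21`, which arises from compound 1 by the change (methyl in place of hydrogen on an aromatic carbon). Among the measured compounds shown here, this is the same kind of change as the one from compound 2 to compound 3, but not the same: in compound 4 the entering methyl sits ortho to a large group, whereas in compound 3 it sits meta to a large group and para to a methyl group.

Because the measured step of a number 1.50 log units lower from compound 2 to compound 3 (beyond the scatter) comes from the second methyl on a ring that already carries one, it is not a direct guide for the first methyl placed in compound 4. Compound 2 already bears that single methyl and still gives 9.9, so a milder step is expected for compound 4: an estimated a number 0.30 log units lower from compound 1 to compound 4 (within the scatter) in this assay. Compound 4 is therefore expected to give about 10.2, most likely between 9.5 and 10.7.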

Compound 4, negative logarithm of the antagonist equilibrium constant: 10.9
For compound 4 the middle estimate is 0.70 log units below the measured one; the measured number lies above the stated range.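

In this assay, methyl in place of hydrogen on an aromatic carbon gave a number 0.40 log units higher from compound 1 to compound 4 (beyond the scatter), so in this series the change does not carry from one core to another as a fixed increment, and the two known steps do not even share a direction: the same change on two cores in this assay, a number 1.50 log units lower (beyond the scatter) from compound 2 to compound 3 and a number 0.40 log units higher (beyond the scatter) from compound 1 to compound 4, 1.90 log units apart, beyond the scatter of two such steps

This does not show that the core alone sets the size or direction of the step. Among these compounds, the methyl enters an unsubstituted phenyl ring in compound 1 but a ring that already bears a methyl in compound 2, so the core and the starting ring differ together between the two steps, and with only one step on each core, no rule can be stated for either of them.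

The compounds shown leave open what the second methyl found in compound 3 would do on the core of compound 1, a step that would compare the two cores on a like-for-like change. They also leave open whether a chlorine atom or a trifluoromethyl group, in the place held by the methyl, would keep the value of compound 4 at 10.9 or move it.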